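The source may hold more compounds than are shown below. What is called first, only, known or untested is meant among the compounds shown, and "the series" means these compounds.

Measured so far:
compound 1 `CCn1ccc(-c2ccccc2NCC2=NCCN2)n1` — 25.1 nM
compound 2 `c1ccc(-c2cn[nH]c2)c(NCC2=NCCN2)c1` — 1.26 nM

In an in vitro functional assay on cells (Fibroblast) for agonist activity at Alpha-1A adrenergic receptor (Homo sapiens) (a higher number here means that more compound is needed for the effect, a lower number that less compound is needed), compound 2 gives 1.26 nM, the lowest of the two numbers shown. Compound 1 gives 25.1 nM, and the gap between the two lies well beyond the usual scatter.

Compound 3 `Cn1ccc(-c2ccccc2NCC2=NCCN2)n1` has not been measured yet. It differs from compound 2 in one place: 1-methyl-1H-pyrazol-3-yl in place of 1H-pyrazol-4-yl on an aromatic carbon. Going by the values given here, no measured pair isolates this exact change, so its size can only be judged from the two numbers on hand. A step upward, beyond the scatter, is expected for compound 3 in this assay; the estimated step is a 6.3-fold higher number from compound 2 to compound 3 (0.80 log units; beyond the scatter) because compound 1 already gives 25.1 nM. The estimate for compound 3 is therefore 8 nM, with a range from 2.5 nM to 30 nM.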

Compound 3, half-maximal effective concentration: 3.16 nM
Compound 3: the middle estimate sits 2.5-fold (0.40 log units) above what was measured; the measured number falls inside the stated range.
By their numbers in this assay, from the lowest: compound 2; then compound 3; then compound 1.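

In this assay, going by these compounds alone, the chain on the aromatic nitrogen matters: hydrogen in place of methyl on its saturated carbon gives a 7.9-fold lower number from compound 1 to compound 3 (0.90 log units; beyond the scatter), the first reading of a single change to that chain. The change from 1H-pyrazol-4-yl to 1-methyl-1H-pyrazol-3-yl on the aromatic carbon gives a 2.5-fold higher number from compound 2 to compound 3 (0.40 log units; beyond the scatter), so compound 3, with no hydrogen-bond donor in this group, stays at 3.16 nM, although this single swap alters both the substituent and the point of attachment. Nothing available explains either step.

The compounds shown do not separate the contribution of the added methyl from that of the altered attachment point. Also open, on these data alone, is how a propyl chain or a cyclopropyl group on the same aromatic nitrogen would read in this assay.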